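A Fluoro Swap on the Core of Compound 2

The source may hold more compounds than are shown below. What is called first, only, known or untested is meant among the compounds shown, and "the series" means these compounds.

Measured in a functional assay on HT-29 cells (Homo sapiens) for inhibition, read by CCK-8 assay, with a stated time of 24 h; on this read-out higher numbers stand for weaker inhibition and lower numbers for stronger inhibition:
- Compound 1 `O=C1Nc2ccccc2/C1=C/c1ccc(-c2cn(-c3ccc(F)cc3)nn2)cc1`: 17700 nM
- Compound 2 `O=C1Nc2ccccc2/C1=C/c1ccc(-c2cn(-c3ccccc3Cl)nn2)cc1`: > 20000 nM (a limit, not a number)
- Compound 3 `O=C1Nc2ccccc2/C1=C/c1ccc(-c2cn(-c3cccc(Cl)c3)nn2)cc1`: > 20000 nM (a limit, not a number)

Compound 2 stands at the limit of > 20000 nM in this assay, at which 2 of the 3 values shown sit. Compound 4 `O=C1Nc2ccc(F)cc2/C1=C/c1ccc(-c2cn(-c3ccccc3Cl)nn2)cc1` alters its core: fluoro in place of hydrogen on an aromatic carbon. Within the data shown here, no measured step covers this change. The nearest steps alter only the group on the aromatic nitrogen. Both an at least 1.1-fold higher number from compound 1 to compound 2 (0.05 log units; that floor lies within the scatter) and an at least 1.1-fold higher number from compound 1 to compound 3 (0.05 log units; that floor lies within the scatter) have floors within the scatter, and a step that the two limits leave unreadable from compound 2 to compound 3 cannot be read. No step beyond the scatter is therefore expected in this assay. The estimated change is a number no higher from compound 2 to compound 4 (the limit leaves the size open). Compound 4 is expected at 20000 nM, with an estimated range of 9000 nM to 40000 nM.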

Compound 4, half-maximal inhibitory concentration: 5950 nM
The estimate for compound 4 lay 3.4-fold (0.53 log units) above the measured number; the whole stated range lies above it.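

In this assay, fluoro in place of hydrogen on the core gives an at least 3.3-fold lower number from compound 2 to compound 4 (0.52 log units; beyond the scatter), so this position can move the read-out beyond the scatter and towards stronger inhibition. The earlier steps shown here changed only the group on the aromatic nitrogen, and each either had a floor within the scatter or could not be read. The true size of this step stays open, since compound 2 carries a limit and not a number: the limit of > 20000 nM in this assay, at which 2 of the 4 values shown sit.

On these data alone, whether chloro, methoxy or an amine at this place would act as fluoro does remains open. So does whether fluoro here has the same effect with the 4-fluorophenyl or 3-chlorophenyl group on the nitrogen.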